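Dropping One Chloro from the Benzyl Ring

A few compounds are considered here, and "the series" means these few. Any claim that something is new, unique, unknown or untested is made for them only; others in the source may bear on it.

Compound 1 `O=S(=O)(NCCCNCc1ccc(Cl)c(Cl)c1)c1cc(C(F)(F)F)cc(C(F)(F)F)c1` gives 1800 nM in a functional assay on Capan-2 cells (Homo sapiens) for inhibition, read by MTT assay, with a stated time of 72 h (on this read-out higher numbers stand for weaker inhibition of growth and lower numbers for stronger inhibition of growth), the lowest of the three numbers seen so far. Compound 3 `COc1ccc(CNCCCNS(=O)(=O)c2cc(C(F)(F)F)cc(C(F)(F)F)c2)cc1` gives 2400 nM, and the step of a 1.3-fold higher number from compound 1 to compound 3 (0.12 log units; within the scatter) stays within the scatter. Compound 2 `CN(CCCNS(=O)(=O)c1cc(C(F)(F)F)cc(C(F)(F)F)c1)Cc1ccccc1` gives 46000 nM, and the step of a 26-fold higher number from compound 1 to compound 2 (1.41 log units; beyond the scatter) is large. Compound 4 `O=S(=O)(NCCCNCc1cccc(Cl)c1)c1cc(C(F)(F)F)cc(C(F)(F)F)c1` differs from compound 1 by hydrogen in place of chloro on an aromatic carbon. Within the data shown here, no measured step removes a single chloro from this aromatic ring. The nearest guide is a 1.3-fold higher number from compound 1 to compound 3 (0.12 log units; within the scatter), where exchanging the whole substituent pattern of that ring changed little, while the large step of a 26-fold higher number from compound 1 to compound 2 (1.41 log units; beyond the scatter) came from a change at the amine nitrogen rather than on the ring. A step within the scatter is therefore expected, a 1.4-fold higher number from compound 1 to compound 4 (0.14 log units; within the scatter). Compound 4 is estimated at 2500 nM, with a range from 1200 nM to 5500 nM.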

Compound 4, concentration for 50% growth inhibition: 8000 nM
The estimate for compound 4 lay 3.2-fold (0.51 log units) below the measured number; the measured number lies above the stated range.
By their numbers in this assay, from the lowest: compounds 1 and 3 (each within the scatter of the next); then compound 4; then compound 2.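

Removing one chloro at this ring carbon, ortho to a chloro group and para to a large group, has a real cost, with a 4.4-fold higher number from compound 1 to compound 4 (0.65 log units; beyond the scatter) beyond the scatter, even though replacing the ring's whole substituent pattern had not moved the number beyond it. A 4-methoxyphenyl ring outperforms the 3-chlorophenyl ring, giving a 3.3-fold higher number from compound 3 to compound 4 (0.52 log units; beyond the scatter), while the benzyl(methyl)amino group remains much poorer, giving a 5.8-fold lower number from compound 2 to compound 4 (0.76 log units; beyond the scatter). Nothing measured here explains these shifts.

On these data alone, whether fluoro, bromo or methyl at that carbon could restore the number remains open.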